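From methoxymethoxy to (ethoxycarbonyl)amino: an expected step

The source may report more compounds than this note shows. Statements on the series, on what has been measured and on what is new or still open speak of the compounds shown alone.

Compound 1 `O=c1cc(O)c2ccc(OCc3cccc(Br)c3)cc2o1`: 0%
Compound 2 `CCOc1cc(=O)oc2cc(OCc3cccc(F)c3)ccc12`: 25%
Compound 3 `COCOc1cc(=O)oc2cc(OCc3cccc(Cl)c3)ccc12`: 23%

These three compounds were tested in an assay on isolated protein (strain Sprague-Dawley) for inhibition of Amine oxidase [flavin-containing] A (Rattus norvegicus), read by spectrophotometry, with a stated time of 5 min, tested at 10 uM; on this read-out lower numbers stand for less inhibition and higher numbers for more inhibition at the one concentration tested (going by the name of the read-out). Compound 3 stands second highest of the three numbers; its value lies within the scatter of compound 2 and beyond the scatter above compound 1. Compound 4 `CCOC(=O)Nc1cc(=O)oc2cc(OCc3cccc(Cl)c3)ccc12` has not yet been measured. It differs from compound 3 in one place: (ethoxycarbonyl)amino in place of methoxymethoxy on an aromatic carbon. Going by the values given here, no step between measured compounds touches this position, so there is no direct guide. With compounds 2 and 3 close together, a step from compound 3 to compound 4 of no more than the scatter is expected in this assay, in either direction. Compound 4 is expected to give 20%, from 5% to 40%. The expected step is a number 3 percentage points lower from compound 3 to compound 4 (within the scatter), within the scatter.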

Compound 4, a percentage reported as inhibition, at one concentration (the size of the read-out at that concentration, not a potency): 21%
For compound 4 the middle estimate is 1 percentage points below the measured one, within the range that was stated.
By their numbers in this assay, from the lowest: compound 1; then compounds 4, 3 and 2 (each within the scatter of the next).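

In this assay, this position opposite the ring oxygen now has its first direct comparison: (ethoxycarbonyl)amino in place of methoxymethoxy gives a number 2 percentage points lower from compound 3 to compound 4 (within the scatter). The change brings in a larger group with a hydrogen-bond donor and a double bond outside the aromatic rings, yet the two compounds stay within the scatter of each other. Nothing available accounts for this result. On these data alone, whether a free amine, a carboxylic acid or a longer chain at this position would give a step beyond the scatter remains open.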